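Swapping a Carbamate Tail on a Kinase Inhibitor

The source may report more compounds than this note shows. Statements on the series, on what has been measured and on what is new or still open speak of the compounds shown alone.

Three compounds share one core and differ only in the group on a saturated chain carbon bound to an oxygen next to a carbonyl group. In an assay for inhibition of serine/threonine-protein kinase PAK 4 (Homo sapiens), read by FRET and Z'-LYTE, with a stated time of 60 min, tested at 0.5 uM, in the presence of a further agent that is not named here (on this read-out higher numbers stand for a stronger effect at the one concentration tested and lower numbers for a weaker effect), compound 1 `CC(C)COC(=O)N1CCN(C(=O)c2nc(Nc3cc(C4CC4)[nH]n3)c3cc(Cl)ccc3n2)C[C@H]1C` gives 0.8%, compound 2 `CC(C)C(=O)OCOC(=O)N1CCN(C(=O)c2nc(Nc3cc(C4CC4)[nH]n3)c3cc(Cl)ccc3n2)C[C@H]1C` gives 16.4%, and compound 3 `C[C@@H]1CN(C(=O)c2nc(Nc3cc(C4CC4)[nH]n3)c3cc(Cl)ccc3n2)CCN1C(=O)OCc1ccccc1` gives 4.4%. Compound 3 stands apart from compound 2 alone: a number 12 percentage points lower from compound 2 to compound 3 (beyond the scatter), whereas a number 3.6 percentage points higher from compound 1 to compound 3 (within the scatter). Compound 4 `C[C@@H]1CN(C(=O)c2nc(Nc3cc(C4CC4)[nH]n3)c3cc(Cl)ccc3n2)CCN1C(=O)OCC(Cl)(Cl)Cl` carries trichloromethyl in place of phenyl on a saturated chain carbon bound to an oxygen next to a carbonyl group. Among the compounds with values here, no measured step involves trichloromethyl, so the only guidance is that replacing isopropyl with phenyl stayed within the scatter in a number 3.6 percentage points higher from compound 1 to compound 3 (within the scatter), while the single larger shift, a number 12 percentage points lower from compound 2 to compound 3 (beyond the scatter), involved a different group. The change is therefore expected to bring a number 0.6 percentage points higher from compound 3 to compound 4 (within the scatter), not beyond the scatter. Compound 4 is estimated at 5%, within a range from -2% to 15%.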

Compound 4, a percentage reported as inhibition, at one concentration (the size of the read-out at that concentration, not a potency): -1.5%
Compound 4: middle estimate off by 6.5 percentage points, on the high side; the measured number falls inside the stated range.
By their numbers in this assay, from the lowest: compounds 4, 1 and 3 (each within the scatter of the next); then compound 2.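

Trichloromethyl, which has no ring, gives a number much like phenyl and isopropyl at this position, with a number 5.9 percentage points lower from compound 3 to compound 4 (within the scatter) and a number 2.3 percentage points lower from compound 1 to compound 4 (within the scatter) in this assay, so a ring on this carbon is not needed to give these numbers. Only compound 2 stands apart, and a number 17.9 percentage points lower from compound 2 to compound 4 (beyond the scatter) is the widest step in the set. Nothing measured here explains that gap. On these data alone, it remains open whether an amine, a carboxylic acid or a longer chain on this carbon would match compound 2 or the other three.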